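The source may hold more compounds than are shown below. What is called first, only, known or untested is meant among the compounds shown, and "the series" means these compounds.

Working notes on the series: the compounds share one core and differ in the group on an oxygen on an aromatic ring. In a functional assay on BT-474 cells (Homo sapiens) for inhibition, read by CellTiter-Glo, with a stated time of 72 h (a higher number here means a weaker inhibitor, a lower number a stronger inhibitor), compound 1 `Cc1cc(Nc2ncnc3cc(O)c(NC(=O)/C=C/[C@H]4CCCN4C)cc23)ccc1Oc1ccn2ncnc2c1` gives (2.4 nM) and compound 2 `Cc1cc(Nc2ncnc3cc(O)c(NC(=O)/C=C/[C@H]4CCCN4C)cc23)ccc1Oc1cc2nccn2cn1` gives (5.59 nM). Compound 3 `Cc1cc(Nc2ncnc3cc(O)c(NC(=O)/C=C/[C@H]4CCCN4C)cc23)ccc1Oc1ccc2nccn2c1` gives (5.22 nM) and holds the second highest of the three numbers. The step (a 1.1-fold lower number from compound 2 to compound 3 (0.03 log units; within the scatter)) lies within the scatter, whereas the step (a 2.2-fold higher number from compound 1 to compound 3 (0.34 log units; beyond the scatter)) is modest and beyond it.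

Compound 4 `Cc1cc(Nc2ncnc3cc(O)c(NC(=O)/C=C/[C@H]4CCCN4C)cc23)ccc1Oc1ccn2cnnc2c1` carries one change from compound 3: a group of 9 heavy atoms (6 carbon, 3 nitrogen; one five-membered aromatic ring with 3 hetero atoms, one six-membered aromatic ring with 1 hetero atom) in place of a group of 9 heavy atoms (7 carbon, 2 nitrogen; one five-membered aromatic ring with 2 hetero atoms, one six-membered aromatic ring with 1 hetero atom), on an oxygen on an aromatic ring at the same oxygen. The entering group has a five-membered aromatic ring with 3 hetero atoms and a six-membered aromatic ring with 1 hetero atom, the same counts as the group in compound 1. The two groups are not identical, however, so compound 1 is only a partial guide.

The closest evidence is the modest step (a 2.2-fold higher number from compound 1 to compound 3 (0.34 log units; beyond the scatter)), read in reverse. The step (a 2.3-fold higher number from compound 1 to compound 2 (0.37 log units; beyond the scatter)) is of similar size. A lower number is therefore expected in this assay, but a smaller move than the full reverse step, given the different arrangement. The expected step is (a 1.6-fold lower number from compound 3 to compound 4 (0.21 log units; within the scatter)) and it remains an estimate. For compound 4 the estimated value is (3.2 nM) with an expected range from 1.4 nM to 7 nM in this measurement.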

Compound 4, half-maximal inhibitory concentration: 26.8 nM
Beside the measured number, compound 4's estimate is 8.4-fold (0.92 log units) below it; measured number above the stated range.
By their numbers in this assay, from the lowest: compound 1; then compounds 3 and 2 (each within the scatter of the next); then compound 4.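

The result shows that the heavy-atom and ring counts of the group on this oxygen do not settle the number in this assay: two groups with identical counts, differing only in how their atoms are arranged, give (an 11-fold higher number from compound 1 to compound 4 (1.05 log units; beyond the scatter)). The change from the group in compound 3 to the group in compound 4 gives (a 5.1-fold higher number from compound 3 to compound 4 (0.71 log units; beyond the scatter)), and the comparison with the other group containing three nitrogens gives (a 4.8-fold higher number from compound 2 to compound 4 (0.68 log units; beyond the scatter)), so a higher count of hetero atoms in the five-membered aromatic ring does not by itself track the number, with compound 1 going against any such reading. Nothing at hand explains why the two arrangements differ.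

The compounds shown leave open how much of the gap belongs to the arrangement of the ring nitrogens alone, since all four groups have 9 heavy atoms and the same two-ring form. Also open, going by these compounds, is whether a methyl or an amine on the five-membered aromatic ring would move the number in the same way with each arrangement.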